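The compounds below may be only part of what the source reports. "The series", "measured", "known", "first", "only" and "open" are said of these compounds alone.

Values in an ADME assay on cells (Hepatocyte, Mus musculus) for metabolic stability, with a stated time of 30 min; a higher number here means that more of the compound is left, a lower number that less of the compound is left:

- compound 1 `O=C(NC1CCC(CN2CCN(c3cc(=O)c4cc(C(F)(F)F)cc([N+](=O)[O-])c4s3)CC2)CC1)c1ccccc1`: 90.6%
- compound 2 `COc1ccc(C(=O)OC2CCC(CN3CCN(c4cc(=O)c5cc(C(F)(F)F)cc([N+](=O)[O-])c5s4)CC3)CC2)cc1`: 31%

Compound 2 holds the lower of the two numbers, 31%. Compound 3 `O=C(OC1CCC(CN2CCN(c3cc(=O)c4cc(C(F)(F)F)cc([N+](=O)[O-])c4s3)CC2)CC1)c1cccs1` differs from it by thiophen-2-yl in place of 4-methoxyphenyl on a carbonyl carbon. The oxygen next to that carbonyl group stays.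

Going by the values given here, only one measured step bears on this change: a number 59.6 percentage points lower from compound 1 to compound 2 (beyond the scatter). That step is large and beyond the scatter, but it exchanges benzamido for ((4-methoxyphenyl)carbonyl)oxy, so it is not the same change. Among the compounds with values here, no measured pair varies the group on the carbonyl carbon alone, so its size carries over poorly. Compound 3 shares more with compound 2, at 31%, than with compound 1, so a small step with a slight downward lean is expected, though the direction is uncertain. The expected step is a number 5 percentage points lower from compound 2 to compound 3 (within the scatter). The estimate for compound 3 is 26%, with an expected range of 8% to 50%.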

Compound 3, percent of the compound remaining: 1.8%
The estimate for compound 3 lay 24.2 percentage points above the measured number, outside the stated range (below it).
By their numbers in this assay, from the lowest: compound 3; then compound 2; then compound 1.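

In this assay the group on the carbonyl carbon proves to matter on its own, with the oxygen next to a carbonyl group kept: thiophen-2-yl in place of 4-methoxyphenyl gives a number 29.2 percentage points lower from compound 2 to compound 3 (beyond the scatter) and the earlier pair could not separate this group from the link. The size of the drop on leaving benzamido therefore depends on what sits on that carbonyl carbon, as a number 88.8 percentage points lower from compound 1 to compound 3 (beyond the scatter) exceeds the step seen with the 4-methoxyphenyl group. No data on hand speak to the cause of either step.

Open, as far as these compounds go, is whether thiophen-2-yl keeps a high number when joined through the amide link of benzamido. Also open, from the compounds shown here alone, is where an unsubstituted phenyl or a furan-2-yl on the same carbonyl carbon would fall relative to compound 2 and compound 3.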